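Swapping Bromo for Chloro on a Shared Core

A few compounds are considered here, and "the series" means these few. Any claim that something is new, unique, unknown or untested is made for them only; others in the source may bear on it.

Of the compounds shown here, three built on one core have been tested in a functional assay on MCF7 cells (Homo sapiens) for antiproliferative activity, read by MTT assay, with a stated time of 48 h; a higher number here means a weaker inhibitor, a lower number a stronger inhibitor. Compound 1 `Cc1ccc(-c2nnc(NC(=O)/C=C/c3ccc(C(F)(F)F)cc3)s2)cc1` gives 1.1 ug/mL. Compound 2 `Cc1ccc(/C=C/C(=O)Nc2nnc(-c3ccc(Cl)cc3)s2)cc1` gives 1.44 ug/mL. Compound 3 `O=C(/C=C/c1ccc(C(F)(F)F)cc1)Nc1nnc(-c2ccc(Br)cc2)s1` gives 1.58 ug/mL. On these numbers compound 3 stands highest of the three, yet its gaps to compound 2 and to compound 1 both lie within the usual scatter, so the three read as much alike.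

Compound 4 `O=C(/C=C/c1ccc(C(F)(F)F)cc1)Nc1nnc(-c2ccc(Cl)cc2)s1` differs from compound 3 in one place: chloro in place of bromo on an aromatic carbon. Among the measured compounds shown here, of the measured steps, only the one from compound 1 to compound 3 touches that place, where bromo replaced methyl and the number moved by a 1.4-fold higher number from compound 1 to compound 3 (0.16 log units; within the scatter), a shift within the scatter. For the measured compounds named here, no step pairing chloro directly with bromo has been measured; compound 2 carries chloro but differs from compound 3 elsewhere as well, so only its value and that of compound 3, which sit close together, can be set side by side. Chloro in place of bromo is therefore expected to leave the number in this assay within scatter, the step from compound 3 to compound 4 being estimated at a 1.1-fold lower number from compound 3 to compound 4 (0.02 log units; within the scatter). Compound 4 is expected to give 1.5 ug/mL, with a range of 0.8 ug/mL to 2.8 ug/mL.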

Compound 4, half-maximal inhibitory concentration: 1.65 ug/mL
Compound 4: the middle estimate sits 1.1-fold (0.04 log units) below what was measured, and the stated range covers the measured number.
By their numbers in this assay, from the lowest: compounds 1, 2, 3 and 4 (each within the scatter of the next).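

Chloro in place of bromo gives a 1.0-fold higher number from compound 3 to compound 4 (0.02 log units; within the scatter) in this assay, so this direct comparison does not separate the two halogens at this position on the ring. Chloro in place of methyl gives a 1.5-fold higher number from compound 1 to compound 4 (0.18 log units; within the scatter) and stays within the scatter, as bromo in place of methyl did, so all three groups at this position now read alike with trifluoromethyl held constant. At a different place in the molecule, trifluoromethyl in place of methyl gives a 1.1-fold higher number from compound 2 to compound 4 (0.06 log units; within the scatter) with chloro held constant, which adds a second position where a single change leaves the number within the scatter.

The data offer no explanation for why these groups read so alike. From the compounds shown here alone, whether the same holds for an amine or a carboxylic acid at either position remains open.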